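Bromo in place of hydrogen on compound 2

A few compounds are considered here, and "the series" means these few. Any claim that something is new, unique, unknown or untested is made for them only; others in the source may bear on it.

Going by the values given here, in a functional assay on A549 cells (Homo sapiens) for antiproliferative activity, read by sulforhodamine B assay, with a stated time of 48 h (a lower number here means a stronger inhibitor, a higher number a weaker inhibitor), compound 2 (`COc1cc(OC)c2sc(-c3ccc(N/C=C\C(=O)c4cc(OC)c(OC)c(OC)c4)cc3)nc2c1`) gives 21800 nM and stands within the scatter of compound 1 (`COc1cc(C(=O)/C=C\Nc2ccc(-c3nc4cc(OC)c(OC)c(OC)c4s3)cc2)c(Br)c(OC)c1OC`), whose 13600 nM is the only other number. Compound 3 (`COc1cc(OC)c2sc(-c3ccc(N/C=C\C(=O)c4cc(OC)c(OC)c(OC)c4Br)cc3)nc2c1`) differs from compound 2 by bromo in place of hydrogen on an aromatic carbon, ortho to a large group. Among the compounds with values here, no measured pair shows this change alone. Within the data shown here, compound 1 carries a bromo on a different core, and its 13600 nM gives the only indirect guide. In this assay no step beyond the scatter is therefore expected, and the data give no firm direction. The expected change is a 1.4-fold lower number from compound 2 to compound 3 (0.13 log units; within the scatter) and stays within the scatter. For compound 3 the estimate is 16000 nM (expected range 6000 nM to 40000 nM).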

Compound 3, half-maximal inhibitory concentration: 12000 nM
Beside the measured number, compound 3's estimate is 1.3-fold (0.12 log units) above it, and the stated range covers the measured number.
By their numbers in this assay, from the lowest: compounds 3, 1 and 2 (each within the scatter of the next).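

In this assay, going by these compounds alone, the first direct reading of bromo in place of hydrogen on an aromatic carbon, ortho to a large group, is a 1.8-fold lower number from compound 2 to compound 3 (0.26 log units; within the scatter) and so shows no step beyond the scatter at this position. With bromo held in place, hydrogen in place of methoxy on an aromatic carbon of the core gives a 1.1-fold lower number from compound 1 to compound 3 (0.05 log units; within the scatter) and is likewise within the scatter, so neither single change separates these compounds. Nothing measured here offers a reason for either reading.

From the compounds shown here alone, whether any group at the bromo position can move the number beyond the scatter remains open, since only hydrogen and bromo have been compared there. An amine, a carboxylic acid or a longer chain at that carbon could answer this, as could chloro or fluoro.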